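The source may hold more compounds than are shown below. What is called first, only, known or untested is meant among the compounds shown, and "the series" means these compounds.

Measured compounds:
- compound 1 `CCCN(CCC)Cc1ccc(Cl)c(-c2ccccc2OC)c1` — "not active" (no number reported) in a functional assay on HEK293 cells for agonist activity at 5-hydroxytryptamine receptor 7 (Homo sapiens), read by a luciferase reporter and beta-arrestin recruitment, with a stated time of 22 h; on this read-out higher numbers stand for larger maximal responses and lower numbers for smaller maximal responses (no number reported)
- compound 2 `COc1ccccc1-c1cc(C2CCN(C)C2)ccc1Cl` — 51%
- compound 3 `CNCc1ccc(Cl)c(-c2ccccc2OC)c1` — 61%

Among the two numbers, compound 3 gives 61% in this assay, the higher figure, yet its nearest neighbour compound 2, at 51%, sits within the scatter of it: the step of a number 10 percentage points higher from compound 2 to compound 3 (within the scatter) is within the scatter, so no order between these two can be read. Compound 1 returned no number at all.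

Compound 4 `CCCNCc1ccc(Cl)c(-c2ccccc2OC)c1` differs from compound 3 in one place: ethyl in place of hydrogen on a saturated chain carbon bound to an amine nitrogen. Cut one bond further out, the change reads methylamino to propylamino. For the measured compounds named here, no measured step touches this position; the only measured step, a number 10 percentage points higher from compound 2 to compound 3 (within the scatter), concerns a different part and is within the scatter, so it offers no guide. Going by the values given here, the two values of compound 1 and compound 3 show only that the compound carrying propyl groups on the amine nitrogen gave no activity while compound 3 gave 61%.

Compound 4 is therefore expected to fall at 45% in this assay, with a range from 20% to 68%. The step of a number 16 percentage points lower from compound 3 to compound 4 (beyond the scatter) is expected to be downward and modest, near the edge of the scatter.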

Compound 4, largest response reached (Emax), in percent of the reference or control that the assay uses: "not active" (no number reported)
Compound 4: no number reported; the estimate stays without a comparison.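

In this assay, for the compounds shown here, compound 4 gives "not active" (no number reported) and so offers no number to set against compound 3, leaving no step to read. The compounds shown leave open how far the response depends on the chain on the amine nitrogen. Nothing shown bears on the reason for this result.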